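The source may hold more compounds than are shown below. What is called first, only, known or untested is meant among the compounds shown, and "the series" means these compounds.

In an ADME assay on microsomes from liver (Homo sapiens) for metabolic stability, read by LC-MS, with a stated time of 45 min, tested at 2 uM (on this read-out higher numbers stand for a more stable compound and lower numbers for a less stable compound), compound 1 `Cc1cc(OCc2ccc(F)cc2F)c(Br)c(=O)n1Cc1ccc(CN(C)C)cc1` gives 57% and compound 2 `Cc1cc(OCc2ccc(F)cc2F)c(Br)c(=O)n1Cc1ccc(C(N)=O)cc1` gives 89% as the higher of the two numbers. Going by the values given here, the one measured step is a number 32 percentage points higher from compound 1 to compound 2 (beyond the scatter) and it comes with carbamoyl in place of (dimethylamino)methyl on an aromatic carbon. Compound 3 `Cc1cc(OCc2ccc(F)cc2F)c(Br)c(=O)n1Cc1ccc(CNC(=O)CO)cc1` has yet to be measured. Its difference from compound 2 reads (((hydroxymethyl)carbonyl)amino)methyl in place of carbamoyl on an aromatic carbon and amounts to (((hydroxymethyl)carbonyl)amino)methyl in place of carbamoyl on an aromatic carbon. Among the compounds with values here, no measured step covers this entering group, so the only guide is the step at the same place, which was large. That step shows how far the read-out can move with a change at this place, but it cannot give the size of the new step. Compound 2 at 89% has little room left above it, so a downward move is expected, smaller than a number 32 percentage points higher from compound 1 to compound 2 (beyond the scatter) seen before. The expected change is a number 15 percentage points lower from compound 2 to compound 3 (beyond the scatter) and it remains a rough estimate. Compound 3 is estimated at 74% with an expected range from 60% to 90% in the coming measurement.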

Compound 3, percent of the compound remaining: 73%
Compound 3: the middle estimate sits 1 percentage points above what was measured, within the range that was stated.
By their numbers in this assay, from the lowest: compound 1; then compound 3; then compound 2.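

At the place on an aromatic carbon of a six-membered aromatic ring of carbon only, the first two compounds showed one change and its large effect on the read-out of this assay; the third compound shows that carbamoyl is not simply interchangeable with another amide-bearing group, with (((hydroxymethyl)carbonyl)amino)methyl giving a number 16 percentage points lower from compound 2 to compound 3 (beyond the scatter). Against the other neighbour, ((hydroxymethyl)carbonyl)amino in place of dimethylamino on a saturated chain carbon bound to an aromatic carbon gives a number 16 percentage points higher from compound 1 to compound 3 (beyond the scatter). Compound 3 therefore stands between the two earlier compounds, so keeping the saturated chain carbon and exchanging only dimethylamino recovers part, but not all, of the difference between compound 1 and compound 2.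

The compounds shown leave open whether the hydroxymethyl end or the amide linkage of the entering group goes with this intermediate number. Going by these compounds, it also remains open whether a carboxylic acid at this place, or a longer chain ending in the same hydroxymethyl carbonyl, would stand nearer compound 2 or compound 1. Nothing shown here accounts for either step.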